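The source may hold more compounds than are shown below. What is called first, only, known or untested is meant among the compounds shown, and "the series" means these compounds.

Measured so far in a functional assay (aorta) with Rattus norvegicus as the target, in the presence of a further agent that is not named here; a lower number here means that less compound is needed, a higher number that more compound is needed for the effect:
compound 1, `COC(=O)C1=C(C)N=C(C)/C(=C(/O)OC)C1c1cccc(OCc2nonc2C(N)=O)c1`, gives 3500 nM;
compound 2, `COC(=O)C1=C(C)N=C(C)/C(=C(/O)OC)C1c1cccc(OCc2c(C(N)=O)no[n+]2[O-])c1`, gives 1200 nM;
compound 3, `COC(=O)C1=C(C)N=C(C)/C(=C(/O)OC)C1c1ccccc1OCc1nonc1C(N)=O`, gives 970 nM.

Among the measured compounds shown here, the change that separates the first two is a group of 9 heavy atoms (3 carbon, 3 nitrogen, 3 oxygen; one five-membered aromatic ring with 3 hetero atoms) in place of a group of 8 heavy atoms (3 carbon, 3 nitrogen, 2 oxygen; one five-membered aromatic ring with 3 hetero atoms), on a saturated chain carbon bound to an oxygen on an aromatic ring. Its step was a 2.9-fold lower number from compound 1 to compound 2 (0.46 log units; beyond the scatter). Compound 3 shares its atoms with compound 1 but joined differently; the difference between the two cores is not broken down here. Compound 3 and compound 2 lie within the scatter of each other in this assay.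

Compound 4, `COC(=O)C1=C(C)N=C(C)/C(=C(/O)OC)C1c1ccccc1OCc1c(C(N)=O)no[n+]1[O-]`, has not been measured. It differs from compound 3 by a group of 9 heavy atoms (3 carbon, 3 nitrogen, 3 oxygen; one five-membered aromatic ring with 3 hetero atoms) in place of a group of 8 heavy atoms (3 carbon, 3 nitrogen, 2 oxygen; one five-membered aromatic ring with 3 hetero atoms), on a saturated chain carbon bound to an oxygen on an aromatic ring, the same change, at the same place, that was made once before. The step is expected to be a 2.6-fold lower number from compound 3 to compound 4 (0.41 log units; beyond the scatter), resting on the earlier step of a 2.9-fold lower number from compound 1 to compound 2 (0.46 log units; beyond the scatter), with some caution; that earlier step is a single instance. Compound 4 is therefore estimated at 380 nM, in a range from 150 nM to 1000 nM.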

Compound 4, half-maximal effective concentration: 560 nM
Compound 4: middle estimate off by 1.5-fold (0.17 log units), on the low side; measured number inside the range.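

In this assay the change gives a 1.7-fold lower number from compound 3 to compound 4 (0.24 log units; within the scatter) and so points the same way as on the first core, although this step alone cannot be told apart from the scatter. The two steps do not differ measurably, so the size seen on one core is compatible with the other: the same change on two cores in this assay, a 2.9-fold lower number (0.46 log units; beyond the scatter) from compound 1 to compound 2 and a 1.7-fold lower number (0.24 log units; within the scatter) from compound 3 to compound 4, 1.7-fold (0.23 log units) apart, within the scatter of two such steps. Among the compounds shown here, with only two pairs, this does not show that the change gives a real effect on the core of compound 3 or that it would carry over to any further core.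

The compounds shown leave open what happens when the carbamoyl group gives way to a nitrile or a carboxylic acid. They also leave open how a longer chain would behave in place of the saturated chain carbon.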